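The compounds below may be only part of what the source reports. "The series", "measured", "known", "first", "only" and "open" are said of these compounds alone.

Of the compounds shown here, three sharing one core have so far been tested in an assay on CHO cells for displacement of a labelled ligand from adenosine receptor A1 (Homo sapiens), read by scintillation counting, tested at 10 uM; a higher number here means more inhibition at the concentration tested (going by the name of the read-out), a lower number less inhibition. Compound 1 `Cc1c(Br)sc(N)c1C(=O)c1ccc(Cl)cc1` gives 1%. Compound 2 `CC(C)(C)Cc1c(-c2cccc(F)c2F)sc(N)c1C(=O)c1ccc(Cl)cc1` gives 1%, and compound 3 `CC(C)(C)Cc1c(-c2ccc(OC(F)(F)F)cc2)sc(N)c1C(=O)c1ccc(Cl)cc1` gives 1%. Compound 2 thus stands level with compound 1 and with compound 3 at the digits shown; neither neighbour differs from it beyond the usual scatter, and none of the three shows inhibition worth speaking of at the concentration tested.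

Compound 4 `Cc1ccccc1-c1sc(N)c(C(=O)c2ccc(Cl)cc2)c1CC(C)(C)C` is the next compound to be measured in this assay. It differs from compound 2 in one place: 2-methylphenyl in place of 2,3-difluorophenyl on an aromatic carbon.

Within the data shown here, no step between any two measured compounds is available to anchor this change. With compound 1, compound 2 and compound 3 all sitting at the same low reading, the expectation for compound 4 is a step of no size beyond the scatter, in no particular direction, so that the step from compound 2 to compound 4 is estimated as a number 1 percentage points higher from compound 2 to compound 4 (within the scatter). Compound 4 is therefore expected to give about 2% in this assay, within a range from 0% to 12%.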

Compound 4, a percentage reported as inhibition, at one concentration (the size of the read-out at that concentration, not a potency): 1%
Beside the measured number, compound 4's estimate is 1 percentage points above it; the range from low to high includes it.
By their numbers in this assay, from the lowest: compounds 1, 2, 3 and 4 (each within the scatter of the next).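

In this assay, among these compounds, putting 2-methylphenyl in place of 2,3-difluorophenyl on the aromatic carbon next to the ring sulfur gives no change at the digits printed from compound 2 to compound 4 (within the scatter), the first direct comparison at this position. Exchanging the two fluorine atoms for one methyl group therefore does not bring out inhibition worth speaking of at the concentration tested. Because both readings are so low, this step cannot show whether the two groups would differ in a compound with clear inhibition, and no other measurement offers an explanation for the flat result.

From the compounds shown here alone, whether an amine or a carboxylic acid on the phenyl ring would give a higher reading remains open. So does whether a morpholine ring in place of the whole phenyl group would change the reading.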